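The source may hold more compounds than are shown below. What is called first, only, known or untested is meant among the compounds shown, and "the series" means these compounds.

Measured so far in a functional assay on BGC-823 cells (Homo sapiens) for cytotoxicity, read by MTT assay, with a stated time of 48 h; a lower number here means a stronger inhibitor, a higher number a weaker inhibitor:
- compound 1 `O=C(CSc1nnc(-c2ccncc2)o1)N/N=C/c1ccc(Br)cc1`: 24500 nM
- compound 2 `O=C(CSc1nnc(-c2ccncc2)o1)N/N=C/c1cccc(F)c1`: 27500 nM
- compound 3 `O=C(CSc1nnc(-c2ccncc2)o1)N/N=C/c1cccc(C(F)(F)F)c1`: 13000 nM

Compound 2 gives the highest number of the three in this assay. Going by the values given here, its nearest neighbour is compound 1, where a 1.1-fold higher number from compound 1 to compound 2 (0.05 log units; within the scatter); the only step beyond the scatter is a 2.1-fold lower number from compound 2 to compound 3 (0.33 log units; beyond the scatter), and that one is modest.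

Compound 4 `O=C(CSc1nnc(-c2ccncc2)o1)N/N=C/c1ccco1` is not yet measured. It differs from compound 2 as follows: furan-2-yl in place of 3-fluorophenyl on a carbon with a double bond to nitrogen. Among the compounds with values here, no measured step exchanges the whole aromatic ring at this position, so neither step bears on it directly; both only show how little this part of the series has moved so far, one step inside the scatter and one modest step beyond it. The expectation is therefore a step that stays within or close to the scatter, with no direction that the data support, so a 1.1-fold lower number from compound 2 to compound 4 (0.04 log units; within the scatter) is expected. For compound 4 in this assay the estimate is 25000 nM, within a range from 10000 nM to 60000 nM.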

Compound 4, half-maximal inhibitory concentration: 25800 nM
For compound 4 the middle estimate is 1.0-fold (0.01 log units) below the measured one, within the range that was stated.
By their numbers in this assay, from the lowest: compounds 3, 1, 4 and 2 (each within the scatter of the next, the first and the last beyond it).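

In this assay, exchanging the whole aromatic ring at this position leaves the number in place: the five-membered furan-2-yl ring stands level with both 3-fluorophenyl (a 1.1-fold lower number from compound 2 to compound 4 (0.03 log units; within the scatter)) and 4-bromophenyl (a 1.1-fold higher number from compound 1 to compound 4 (0.02 log units; within the scatter)). Across compounds 1, 2 and 4, then, a carbon with a double bond to nitrogen accepts a smaller ring with one hetero atom and one hydrogen-bond acceptor without a step beyond the scatter, something the earlier phenyl-only compounds could not show. No supporting data are available to explain this flat result.

Still open, from the compounds shown here alone, is whether a saturated alkyl chain in place of the ring would leave the number equally unmoved. Also open, going by these compounds, is whether an amine or a carboxylic acid on the ring would produce a step beyond the scatter.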